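This account rests on a few compounds, and the source may have more. Where it says the series, first, only, none or still open, it means among the compounds named here.

Three compounds built on one shared core differ only in the group on the phenyl ring. In a functional assay on HepG2 cells (Homo sapiens) for antiproliferative activity (a higher number here means a weaker inhibitor, a lower number a stronger inhibitor), compound 1 `C/C(=N\Nc1nc(-c2ccc(Cl)cc2)cs1)c1cc2ccccc2o1` gives 23200 nM, compound 2 `C/C(=N\Nc1nc(-c2ccc(C)cc2)cs1)c1cc2ccccc2o1` gives 14100 nM, and compound 3 `COc1ccc(-c2csc(N/N=C(\C)c3cc4ccccc4o3)n2)cc1` gives 15700 nM. Compound 3 thus stands second highest of the three, with compound 2 nearest and compound 1 furthest, both within the scatter. Compound 4 `C/C(=N\Nc1nc(-c2ccccc2)cs1)c1cc2ccccc2o1` carries hydrogen in place of methoxy on an aromatic carbon. Among the compounds with values here, the steps that bear on this change, each swapping the group on that aromatic carbon, were a 1.6-fold lower number from compound 1 to compound 2 (0.22 log units; within the scatter), a 1.5-fold lower number from compound 1 to compound 3 (0.17 log units; within the scatter) and a 1.1-fold higher number from compound 2 to compound 3 (0.05 log units; within the scatter), all within the scatter, so in this assay no step beyond the scatter is expected for a 1.0-fold higher number from compound 3 to compound 4 (0.01 log units; within the scatter). Compound 4 is therefore estimated at 16000 nM, within a range from 7000 nM to 36000 nM.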

Compound 4, half-maximal inhibitory concentration: 10300 nM
Compound 4: the middle estimate sits 1.6-fold (0.19 log units) above what was measured; measured number inside the range.
By their numbers in this assay, from the lowest: compounds 4, 2, 3 and 1 (each within the scatter of the next, the first and the last beyond it).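

With hydrogen on this aromatic carbon, the series shows its first step beyond the scatter: in this assay there is a 2.3-fold lower number from compound 1 to compound 4 (0.35 log units; beyond the scatter), a modest change. Hydrogen cannot be told apart from the other two groups, with a 1.5-fold lower number from compound 3 to compound 4 (0.18 log units; within the scatter) and a 1.4-fold lower number from compound 2 to compound 4 (0.14 log units; within the scatter). Of the three groups, only chloro therefore stands apart from hydrogen, and neither methoxy nor methyl does. Nothing available explains that difference. On these data alone, whether an amine or a carboxylic acid on this carbon would shift the number further remains open.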